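The compounds below may be only part of what the source reports. "The series", "measured", "known", "first", "only" and "open" are said of these compounds alone.

Measured in an ADME assay on microsomes from liver (Homo sapiens) for metabolic stability, read by LC-MS, with a stated time of 30 min, tested at 1 uM; on this read-out lower numbers stand for a less stable compound and higher numbers for a more stable compound:
- compound 1 `O=C(NCc1ccc(S(=O)(=O)c2ccccc2)cc1)c1cc2ncccc2s1`: 81%
- compound 2 `O=C(NCc1ccc(S(=O)(=O)c2ccccc2)cc1)c1cn2ccnc2cn1`: 87%

In this assay, compound 2 stands at 87%, level with compound 1 once the scatter is allowed for. Compound 3 `O=C(NCc1ccc(S(=O)(=O)c2ccccc2)cc1)c1c[nH]c2ccncc12` is still unmeasured. It departs from compound 2 on the carbonyl carbon whose other neighbour is the amide-type nitrogen: a group of 9 heavy atoms (7 carbon, 2 nitrogen; one five-membered aromatic ring with 1 hetero atom, one six-membered aromatic ring with 1 hetero atom) in place of a group of 9 heavy atoms (6 carbon, 3 nitrogen; one five-membered aromatic ring with 2 hetero atoms, one six-membered aromatic ring with 2 hetero atoms), on a carbonyl carbon. For the measured compounds named here, only one measured step bears on this change, an exchange at the same place: a number 6 percentage points higher from compound 1 to compound 2 (within the scatter). That single exchange of one group for another of equal heavy-atom count stayed within the scatter, so no step beyond the scatter is expected here, though one step is thin evidence. The estimated step is a number 7 percentage points lower from compound 2 to compound 3 (within the scatter). For compound 3, the expected value is 80%, with an estimated range of 62% to 94%.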

Compound 3, percent of the compound remaining: > 99%
Compound 3 ended at the assay's limit (the forecaster's own chance of this, stated with the estimate: 3%); at least 19 percentage points between middle value and limit.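

Compound 3 stands at a limit of the assay, not at a measured number: the limit of > 99% in this assay, at which 1 of the 3 values shown sits.

For the compounds shown here, the one earlier exchange on this carbonyl carbon had stayed within the scatter, but this position now shows changes beyond it: a number at least 12 percentage points higher from compound 2 to compound 3 (beyond the scatter), and a number at least 18 percentage points higher from compound 1 to compound 3 (beyond the scatter). Among these three compounds, then, groups of equal heavy-atom count are not interchangeable at this place in this assay, and the group in compound 3 separates from both of the others.

The limit leaves the true size of both steps unknown, and the three compounds do not tell whether the hydrogen-bond donor of the entering group or some other feature of it goes with the change. Also open, from the compounds shown here alone, is how a single phenyl ring or a carboxylic acid would read on the same carbonyl carbon.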